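The source may report more compounds than this note shows. Statements on the series, on what has been measured and on what is new or still open speak of the compounds shown alone.

Of the compounds shown here, three with a shared core have been tested in a functional assay on the whole organism (Tail, strain ICR) with Mus musculus as the target, in the tail flick test, with a stated time of 90 min, at a dose of 25 umol/kg by the oral route; on this read-out higher numbers stand for a stronger effect at the one dose given and lower numbers for a weaker effect. Compound 1 `O=C(OCc1ccccc1)[C@@H]1CCCN1C(=O)CN(c1nc(Cl)nc2[nH]cnc12)C1CC1` gives 43.3%. Compound 3 `O=C(CN(c1ncnc2c1ncn2C1CCCCO1)C1CC1)N[C@@H](CO)C(=O)OCc1ccccc1` gives 32.2%. Compound 2 `NC(=O)C[C@H](NC(=O)CN(c1nc(Cl)nc2[nH]cnc12)C1CC1)C(=O)O` gives 20.1%, the lowest of the three numbers; compound 3 stands nearest to it and compound 1 furthest, and both gaps lie beyond the scatter of repeated measurements.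

Compound 4 `NC(=O)CC[C@H](NC(=O)CN(c1nc(Cl)nc2[nH]cnc12)C1CC1)C(=O)O` has not yet been measured. It differs from compound 2 in a single place: carbamoylmethyl in place of carbamoyl on a saturated chain carbon, two bonds along the chain from an amide-type nitrogen and a carbonyl carbon. The chain that carries the amide group grows by one carbon, while the donor and acceptor counted in that group stay the same. Going by the values given here, no pair of measured compounds differs in just one place, so there is no measured step of this kind to lean on. From compound 2 alone, the expected step from compound 2 to compound 4 in this assay is a number 1.9 percentage points higher from compound 2 to compound 4 (within the scatter), which would stay within the scatter. Compound 4 is therefore estimated at 22%, with a likely range from 8% to 38%.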

Compound 4, a percentage reported as activity, at one dose (the size of the read-out at that dose, not a potency): 41.1%
Beside the measured number, compound 4's estimate is 19.1 percentage points below it, and the stated range ends below it.
By their numbers in this assay, from the lowest: compound 2; then compounds 3, 4 and 1 (each within the scatter of the next, the first and the last beyond it).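

In this assay, moving from carbamoyl to carbamoylmethyl on a saturated chain carbon, two bonds along the chain from an amide-type nitrogen and a carbonyl carbon, gives a number 21 percentage points higher from compound 2 to compound 4 (beyond the scatter). Going by these compounds alone, this is the first step that can be read at a single place, and it shows that the read-out responds to the length of this chain, even though the hydrogen-bond donor and acceptor counted in the group stay the same. No measurement available here explains how the longer chain produces this gain.

A single step cannot show whether the effect keeps rising with a longer chain, such as one more carbon before the same amide group, or falls away again. It also leaves open whether the amide itself matters, which an amine or a carboxylic acid at the end of this chain could test.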